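The source may hold more compounds than are shown below. What is called first, only, known or untested is meant among the compounds shown, and "the series" means these compounds.

In a functional assay (CEM-VLB cells, Homo sapiens) for antiproliferative activity, read by sulforhodamine B assay, with a stated time of 48 h (a higher number here means a weaker inhibitor, a lower number a stronger inhibitor), compound 1 `O=C1NCCN1c1ccc(S(=O)(=O)Nc2cccc(Br)c2)cc1` gives 250 nM, compound 2 `Cc1cc(C)cc(NS(=O)(=O)c2ccc(N3CCNC3=O)cc2)c1` gives 400 nM and compound 3 `O=C1NCCN1c1ccc(S(=O)(=O)Nc2cccc(Cl)c2)cc1` gives 170 nM. Two steps show where the last of these stands: a 2.4-fold lower number from compound 2 to compound 3 (0.37 log units; beyond the scatter), and a 1.5-fold lower number from compound 1 to compound 3 (0.17 log units; within the scatter). Compound 4 `COc1cccc(NS(=O)(=O)c2ccc(N3CCNC3=O)cc2)c1`, not yet measured, differs from compound 3 by methoxy in place of chloro on an aromatic carbon. Within the data shown here, no measured compound carries methoxy, so the evidence is indirect. Among these three compounds, changes on this ring have given modest steps at most, with a 1.6-fold higher number from compound 1 to compound 2 (0.20 log units; within the scatter) also inside the scatter. A small rise that stays within the scatter is therefore expected, a 1.5-fold higher number from compound 3 to compound 4 (0.17 log units; within the scatter). Compound 4 is estimated at 250 nM, with an expected range of 120 nM to 500 nM.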

Compound 4, half-maximal inhibitory concentration: 700 nM
Compound 4: the middle estimate sits 2.8-fold (0.45 log units) below what was measured; the whole stated range lies below it.
By their numbers in this assay, from the lowest: compounds 3, 1, 2 and 4 (each within the scatter of the next, the first and the last beyond it).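

Among these compounds, at this place on the ring, the choice of group matters more than the earlier compounds showed: in this assay, methoxy in place of chloro gives a 4.1-fold higher number from compound 3 to compound 4 (0.61 log units; beyond the scatter), and methoxy in place of bromo gives a 2.8-fold higher number from compound 1 to compound 4 (0.45 log units; beyond the scatter), both larger than any earlier step. Set against the 3,5-dimethylphenyl ring, however, 3-methoxyphenyl is not separated, with a 1.8-fold higher number from compound 2 to compound 4 (0.24 log units; within the scatter). Nothing shown here gives a reason for these steps. Still open, on these data alone, is how fluoro, an amine or a carboxylic acid would read at this place. A longer chain such as ethoxy would test whether the oxygen or the added carbon goes with the weaker number.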